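A few compounds are considered here, and "the series" means these few. Any claim that something is new, unique, unknown or untested is made for them only; others in the source may bear on it.

Compound 1 `Cc1cccc(-c2sc(N)c(C(=O)c3ccc(Cl)cc3)c2CC(C)(C)C)c1` gives 1% in an assay on CHO cells for displacement of a labelled ligand from adenosine receptor A3 (Homo sapiens), read by scintillation counting, tested at 10 uM; on this read-out lower numbers stand for less inhibition and higher numbers for more inhibition at the one concentration tested (going by the name of the read-out).
Compound 2 `CC(C)(C)Cc1c(-c2ccccc2)sc(N)c1C(=O)c1ccc(Cl)cc1` gives 1% in this assay.
Compound 3 `COc1ccc(-c2sc(N)c(C(=O)c3ccc(Cl)cc3)c2CC(C)(C)C)cc1` gives 2% in this assay.

All three measured compounds barely move the read-out at the one concentration tested. Compound 3 sits within the scatter of both others: from compound 1 to compound 3 the step is a number 1 percentage points higher from compound 1 to compound 3 (within the scatter), and from compound 2 to compound 3 it is a number 1 percentage points higher from compound 2 to compound 3 (within the scatter). The remaining step, no change at the digits printed from compound 1 to compound 2 (within the scatter), is equally flat. Every one of these steps alters the aromatic group on the shared core, not the group on the carbonyl carbon.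

Compound 4 `COc1ccc(-c2sc(N)c(C(=O)c3cccc(C(F)(F)F)c3)c2CC(C)(C)C)cc1` differs from compound 3 by 3-(trifluoromethyl)phenyl in place of 4-chlorophenyl on a carbonyl carbon. For the measured compounds named here, no measured step touches that part of the molecule, so the data give no direct guide. What they do show is that three variations elsewhere all left the read-out near its floor, and nothing suggests the new change behaves differently. The step from compound 3 to compound 4 is therefore expected to be a number 1 percentage points higher from compound 3 to compound 4 (within the scatter), none beyond the scatter. Compound 4 is estimated at 3%, with a range from -6% to 15%.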

Compound 4, a percentage reported as inhibition, at one concentration (the size of the read-out at that concentration, not a potency): 1%
Compound 4: middle estimate off by 2 percentage points, on the high side; measured number inside the range.
By their numbers in this assay, from the lowest: compounds 1, 2, 4 and 3 (each within the scatter of the next).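

For the compounds shown here, this is the first change on the carbonyl carbon: 3-(trifluoromethyl)phenyl in place of 4-chlorophenyl gives a number 1 percentage points lower from compound 3 to compound 4 (within the scatter) in this assay. The read-out therefore stays flat for this swap too, not only for the changes to the other aromatic group on the shared core. No available evidence bears on why this swap leaves the number where it is.

The compounds shown leave open whether any group on the carbonyl carbon can lift the read-out, for instance a pyridine ring or a cyclohexyl ring in place of the substituted phenyl rings. They also leave open whether changing the amine of the shared core, for example by adding an acetyl group to it, would move the number at all.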